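The source may hold more compounds than are shown below. What is called first, only, known or untested is meant among the compounds shown, and "the series" means these compounds.

Measured in an ADME assay for permeability, using PAMPA, at pH 7.4; on this read-out lower numbers stand for lower permeability and higher numbers for higher permeability:
compound 1 `Cc1cc(NC(=O)Nc2ccc(C(C)(C)C)cc2)c2ccccc2n1`: 142 10^-6 cm/s
compound 2 `Cc1cc(NC(=O)Nc2ccccc2OC(F)(F)F)c2ccccc2n1`: 1110 10^-6 cm/s
compound 3 `Cc1cc(NC(=O)Nc2cccc([N+](=O)[O-])c2)c2ccccc2n1`: 42 10^-6 cm/s

Compound 3 stands lowest of the three, with both gaps beyond the scatter. Compound 1 lies nearest to it and compound 2 furthest. Still unmeasured, compound 4 `COc1cccc(NC(=O)Nc2cc(C)nc3ccccc23)c1` carries methoxy in place of nitro on an aromatic carbon, meta to a large group (methoxy in place of nitro on an aromatic carbon). For the measured compounds named here, no measured pair shows this change, so the expectation rests on the values alone. Neither compound 1 at 142 10^-6 cm/s nor compound 2 at 1110 10^-6 cm/s carries nitro, and both read higher than compound 3. In this assay the expected step is a 4.8-fold higher number from compound 3 to compound 4 (0.68 log units; beyond the scatter), a rise beyond the scatter. The estimate for compound 4 is 200 10^-6 cm/s, with an expected range of 60 10^-6 cm/s to 700 10^-6 cm/s.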

Compound 4, apparent permeability: 818 10^-6 cm/s
Beside the measured number, compound 4's estimate is 4.1-fold (0.61 log units) below it; measured number outside the range, above it.
By their numbers in this assay, from the lowest: compound 3; then compound 1; then compounds 4 and 2 (each within the scatter of the next).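

In this assay, for the compounds shown here, methoxy in place of nitro on an aromatic carbon, meta to a large group, gives a 19-fold higher number from compound 3 to compound 4 (1.29 log units; beyond the scatter), the only single-place step so far. The read-out at this position therefore depends strongly on the group carried there, at least for this one exchange. Nothing measured here accounts for the size of the step.

Going by these compounds, whether the step follows from losing nitro or from gaining methoxy remains open, and an amine or a chlorine at the same place could separate the two. On these data alone, whether the same exchange elsewhere on this ring gives a similar step also remains open.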